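The source may hold more compounds than are shown below. What is called first, only, known or untested is meant among the compounds shown, and "the series" means these compounds.

Compound 1 `O=C(NCCCCc1ccccc1)c1cccc(C2SCC(=O)N2c2cccc(-c3c[nH]nn3)c2)c1`: 110 nM
Compound 2 `O=C(NCCCCc1ccccc1)c1cccc(C2SCC(=O)N2c2ccccn2)c1`: 19.7 nM

In a functional assay on HOS-TE85 cells (Homo sapiens) for inhibition, read by CCK-8 assay, with a stated time of 72 h (a higher number here means a weaker inhibitor, a lower number a stronger inhibitor), compound 2 holds the lower of the two numbers, at 19.7 nM. Compound 3 `CC(F)(F)c1cccc(N2C(=O)CSC2c2cccc(C(=O)NCCCCc3ccccc3)c2)c1` is the next to read, with this change from compound 2: a group of 10 heavy atoms (8 carbon, 2 fluorine; one six-membered aromatic ring of carbon only) in place of a group of 6 heavy atoms (5 carbon, 1 nitrogen; one six-membered aromatic ring with 1 hetero atom), on an amide-type nitrogen in a ring. Pyridin-2-yl leaves the amide-type nitrogen in a ring. For the measured compounds named here, only one measured step changes the group at this place: a 5.6-fold lower number from compound 1 to compound 2 (0.75 log units; beyond the scatter). In compound 1, a group with a six-membered aromatic ring of carbon only gave the higher number, 110 nM. A modest rise is therefore expected, with the expected step being a 2.5-fold higher number from compound 2 to compound 3 (0.40 log units; beyond the scatter). The estimate for compound 3 is 50 nM, within 15 nM to 170 nM.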

Compound 3, half-maximal inhibitory concentration: 29.1 nM
The estimate for compound 3 lay 1.7-fold (0.24 log units) above the measured number; the range from low to high includes it.
By their numbers in this assay, from the lowest: compounds 2 and 3 (each within the scatter of the next); then compound 1.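

In this assay, a six-membered aromatic ring of carbon only on the amide-type nitrogen need not give the higher number: 1,1-difluoroethyl in place of 1H-1,2,3-triazol-4-yl on that ring gives a 3.8-fold lower number from compound 1 to compound 3 (0.58 log units; beyond the scatter). Replacing pyridin-2-yl with this substituted ring gives a 1.5-fold higher number from compound 2 to compound 3 (0.17 log units; within the scatter), so the ring nitrogen of pyridin-2-yl is not required at this position for a number in this range. No evidence on hand bears on either step.

On these data alone, it remains open how a carboxylic acid or an amine in place of 1,1-difluoroethyl would read. As far as these compounds go, the unsubstituted phenyl ring, which would separate the effect of the ring from that of its substituent, is also open.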